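A few compounds are considered here, and "the series" means these few. Any claim that something is new, unique, unknown or untested is made for them only; others in the source may bear on it.

Measured so far in a functional assay on CHO cells with adenosine receptor A1 (Homo sapiens) as the target, read by cAMP accumulation and immunoassay, with a stated time of 6 min, tested at 1 uM; on this read-out lower numbers stand for a stronger effect and higher numbers for a weaker effect at the one concentration tested:
compound 1 `Nc1scc(CN2CCN(c3ccccc3C(F)(F)F)CC2)c1C(=O)c1ccc(Cl)cc1` gives -39%;
compound 2 `Nc1scc(CN2CCN(c3ccc(F)c(F)c3)CC2)c1C(=O)c1ccc(Cl)cc1` gives -78%;
compound 3 `Nc1scc(CN2CCN(c3cccc(F)c3F)CC2)c1C(=O)c1ccc(Cl)cc1` gives -66%.

Compound 3 stands second highest of the three numbers. Its nearest neighbour is compound 2: a number 12 percentage points higher from compound 2 to compound 3 (beyond the scatter). Its furthest is compound 1: a number 27 percentage points lower from compound 1 to compound 3 (beyond the scatter). Compound 4 `Nc1scc(CN2CCN(c3ccc(Cl)c(Cl)c3)CC2)c1C(=O)c1ccc(Cl)cc1` differs from compound 3 by 3,4-dichlorophenyl in place of 2,3-difluorophenyl on an amine nitrogen in a ring. Within the data shown here, the one measured step that bears on this change is the exchange of substitution pattern, a number 12 percentage points higher from compound 2 to compound 3 (beyond the scatter), a modest step. Among the measured compounds shown here, no measured step exchanges fluorine for chlorine, so that part of the change has no precedent here; the largest step, a number 39 percentage points lower from compound 1 to compound 2 (beyond the scatter), only shows how wide the spread can be. A modest move in the direction of compound 2 is therefore expected, a number 7 percentage points lower from compound 3 to compound 4 (within the scatter). Compound 4 is estimated at -73%, with a range from -92% to -52%.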

Compound 4, a percentage reported as activity, at one concentration (the size of the read-out at that concentration, not a potency): -60%
Beside the measured number, compound 4's estimate is 13 percentage points below it; the measured number falls inside the stated range.
By their numbers in this assay, from the lowest: compound 2; then compounds 3 and 4 (each within the scatter of the next); then compound 1.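

With the substitution pattern held, 3,4-dichlorophenyl in place of 3,4-difluorophenyl gives a number 18 percentage points higher from compound 2 to compound 4 (beyond the scatter), so at this position on the ring amine nitrogen the identity of the halogen matters as well as its pattern. 3,4-Dichlorophenyl is not separated from 2,3-difluorophenyl, at a number 6 percentage points higher from compound 3 to compound 4 (within the scatter), yet it still differs from 2-(trifluoromethyl)phenyl, at a number 21 percentage points lower from compound 1 to compound 4 (beyond the scatter). No measurement at hand explains these steps. The compounds shown leave open how a methoxy group, or a single chlorine, on this phenyl ring would read.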